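This account rests on a few compounds, and the source may have more. Where it says the series, first, only, none or still open, it means among the compounds named here.

Of the compounds shown here, two sharing one core have been measured in a functional assay on HaCaT cells (Homo sapiens) for antiproliferative activity, read by sulforhodamine B assay, with a stated time of 3 days; on this read-out lower numbers stand for stronger inhibition and higher numbers for weaker inhibition. Compound 1 `COC(=O)c1cc(CCc2cc(O)ccc2OC)ccc1O` gives 8700 nM, and compound 2 `COC(=O)c1cc(CCc2cc(SC)ccc2OC)ccc1O` gives 860 nM. Among the measured compounds shown here, the one measured step, a 10-fold lower number from compound 1 to compound 2 (1.01 log units; beyond the scatter), came from putting methylsulfanyl in place of hydroxy on an aromatic carbon. For the measured compounds named here, compound 2 thus holds the lowest number of the two, with compound 1 as its only neighbour. Compound 3 `CCc1ccc(OC)c(CCc2ccc(O)c(C(=O)OC)c2)c1` has not been measured yet; it differs from compound 2 by ethyl in place of methylsulfanyl on an aromatic carbon. Going by the values given here, the single measured step touches the same position but not this exchange: it shows that a change at this place can move the read-out a great deal, yet says nothing about ethyl set against methylsulfanyl. With no closer guide, the expectation for compound 3 is a step of a 1.2-fold higher number from compound 2 to compound 3 (0.07 log units; within the scatter), within the scatter. The estimated value for compound 3 is 1000 nM, with a range from 400 nM to 2500 nM.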

Compound 3, half-maximal inhibitory concentration: 430 nM
Compound 3: middle estimate off by 2.3-fold (0.37 log units), on the high side; measured number inside the range.
By their numbers in this assay, from the lowest: compounds 3 and 2 (each within the scatter of the next); then compound 1.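

In this assay, the step of a 2.0-fold lower number from compound 2 to compound 3 (0.30 log units; within the scatter) means that ethyl and methylsulfanyl cannot be told apart at this position. The step of a 20-fold lower number from compound 1 to compound 3 (1.31 log units; beyond the scatter) is large, so replacing hydroxy with ethyl has much the same outcome as replacing it with methylsulfanyl, and among these three compounds a sulfur atom at this place is not needed for the lower numbers. No measurement shown here accounts for the difference between hydroxy and the other two groups.

As far as these compounds go, what remains open is how far this position can be changed: a longer chain such as propyl might keep the number near those of compound 2 and compound 3, or might not. An amine in the same place could fall with hydroxy or with ethyl, and the compounds shown do not tell which.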